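The source may hold more compounds than are shown below. What is called first, only, known or untested is meant among the compounds shown, and "the series" means these compounds.

In a physicochemical assay for solubility, at pH 1.1 (on this read-out higher numbers stand for higher solubility and lower numbers for lower solubility), compound 2 `CCN(Cc1ccc(OCCN2C(=O)CCC2=O)c(C)c1)C(CC(=O)O)c1ccc(Cl)cc1` gives 3000000 nM. It stands level with its two measured relatives: compound 1 `CCCN(Cc1ccc(OCCN2C(=O)CCC2=O)c(C)c1)[C@@H](CC(=O)O)c1ccc(Cl)cc1` gives 3000000 nM, and compound 3 `Cc1cc(CN(CC2CCCC2)[C@@H](CC(=O)O)c2ccc(Cl)cc2)ccc1OCCN1C(=O)CCC1=O` gives 3000000 nM. Compound 4 `Cc1cc(CN(CCC(F)(F)F)C(CC(=O)O)c2ccc(Cl)cc2)ccc1OCCN1C(=O)CCC1=O` has not been measured yet. It differs from compound 2 by trifluoromethyl in place of hydrogen on a saturated chain carbon, two bonds along the chain from an amine nitrogen, so that ethyl becomes 3,3,3-trifluoropropyl. Among the compounds with values here, the one measured step that bears on this, cyclopentyl in place of ethyl on a saturated chain carbon bound to an amine nitrogen, showed no change at the digits printed from compound 1 to compound 3 (within the scatter). Within the data shown here, with only that evidence, no shift in either direction beyond the scatter is expected in this assay. The expected move is no change at the digits printed from compound 2 to compound 4 (within the scatter). For compound 4 the estimated value is 3000000 nM, within a range of 1500000 nM to 3500000 nM.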

Compound 4, solubility: 3000000 nM
The estimate for compound 4 equals the measured number at the digits printed, within the range that was stated.
By their numbers in this assay, from the lowest: compounds 1, 2, 3 and 4 (each within the scatter of the next).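

In this assay turning ethyl into 3,3,3-trifluoropropyl gives no change at the digits printed from compound 2 to compound 4 (within the scatter) at this position. Within the data shown here, the earlier compounds carried only carbon and hydrogen in this group on the amine nitrogen, so this is the first case here with fluorine on that chain, and the printed value stays the same. No measured information is available to explain this result. Still open, going by these compounds, is whether an amine or a carboxylic acid at the end of this chain would shift the value. A longer chain also remains to be compared.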